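Swapping Pyridinyl for Benzyloxy in Compound 4

A few compounds are considered here, and "the series" means these few. Any claim that something is new, unique, unknown or untested is made for them only; others in the source may bear on it.

Compound 1 `C[C@@H]1CN(c2cccc(NS(=O)(=O)c3ccc(-c4ccccn4)s3)c2)C[C@H](C)N1`: 39.8 nM in a functional assay for agonist activity at growth hormone secretagogue receptor type 1 (Homo sapiens), read by FLIPR; a higher number here means that more compound is needed for the effect, a lower number that less compound is needed
Compound 2 `C[C@@H]1CN(c2ccc(F)c(NS(=O)(=O)c3ccc(-c4ccccn4)s3)c2)C[C@H](C)N1`: 100 nM
Compound 3 `COc1ccc(N2C[C@@H](C)N[C@@H](C)C2)cc1NS(=O)(=O)c1ccc(-c2ccncc2)cc1`: 316 nM

Compound 3 stands highest of the three numbers in this assay, with compound 2 and compound 1 both clearly lower. Compound 4 `COc1ccc(N2C[C@@H](C)N[C@@H](C)C2)cc1NS(=O)(=O)c1ccc(OCc2ccccc2)cc1` differs from compound 3 by benzyloxy in place of pyridin-4-yl on an aromatic carbon. Within the data shown here, the only measured step, a 2.5-fold higher number from compound 1 to compound 2 (0.40 log units; beyond the scatter), involves a fluoro on a different ring and does not bear on this swap. Among the measured compounds shown here, no measured pair shows what replacing the pyridinyl with a benzyloxy does, so the expected change in this assay is undetermined in direction, and only a wide band can be given. Compound 4 is therefore estimated at 400 nM, between 100 nM and 1600 nM, a step of a 1.3-fold higher number from compound 3 to compound 4 (0.10 log units; within the scatter) that is expected to stay close to compound 3.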

Compound 4, half-maximal effective concentration: 100 nM
Compound 4: the middle estimate sits 4.0-fold (0.60 log units) above what was measured, and the stated range covers the measured number.
By their numbers in this assay, from the lowest: compound 1; then compounds 2 and 4 (each within the scatter of the next); then compound 3.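

In this assay, among these compounds, benzyloxy in place of pyridin-4-yl gives a 3.2-fold lower number from compound 3 to compound 4 (0.50 log units; beyond the scatter), the first measured change at this position, para to a large group. Here, less compound is needed with the larger group, which has 8 heavy atoms against 6, so a nitrogen-containing ring directly on the carbon is not required for activity in this pair. No measurement available here accounts for this shift. This single step changes the ring and adds an oxygen-containing link at once, and the compounds shown do not separate the two. From the compounds shown here alone, how a plain phenyl or a benzylamino group would read at this position remains open.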